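Methyl on the amide nitrogen after a large loss

A few compounds are considered here, and "the series" means these few. Any claim that something is new, unique, unknown or untested is made for them only; others in the source may bear on it.

Compound 2 `NC(=O)c1cc(-c2ccc(NS(=O)(=O)c3cccc(Cl)c3Cl)cc2)nc2[nH]ncc12` stands highest of the two numbers in an assay for inhibition of serine/threonine-protein kinase Sgk1 (Homo sapiens), with stated times of 30 min and 60 min, in the presence of a further agent that is not named here; a higher number here means a weaker inhibitor, a lower number a stronger inhibitor; in this assay compound 2 gives 236 nM. Compound 1 `CC(C)N1CC[C@H](NC(=O)c2cc(-c3ccc(NS(=O)(=O)c4cccc(Cl)c4Cl)cc3)nc3[nH]ncc23)C1` gives 38 nM in this assay, and the step of a 6.2-fold higher number from compound 1 to compound 2 (0.79 log units; beyond the scatter) shows the cost of removing the group on the amide nitrogen. Compound 3 `CNC(=O)c1cc(-c2ccc(NS(=O)(=O)c3cccc(Cl)c3Cl)cc2)nc2[nH]ncc12` differs from compound 2 by methyl in place of hydrogen on an amide-type nitrogen. Among the measured compounds shown here, only that one step bears on this change, and a methyl restores only a small part of what compound 1 carried, so a step of modest size or none beyond the scatter is expected. Compound 3 is estimated at 150 nM in this assay, range 60 nM to 400 nM. The expected step is a 1.6-fold lower number from compound 2 to compound 3 (0.20 log units; within the scatter).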

Compound 3, half-maximal inhibitory concentration: 929 nM
Estimate against measurement, compound 3: 6.2-fold (0.79 log units) below; measured number above the stated range.
By their numbers in this assay, from the lowest: compound 1; then compound 2; then compound 3.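

On the amide nitrogen in this assay, methyl does not recover part of what compound 1 carries: the number moves the opposite way, with a 3.9-fold higher number from compound 2 to compound 3 (0.60 log units; beyond the scatter). The gap to the larger group widens to a 24-fold higher number from compound 1 to compound 3 (1.39 log units; beyond the scatter), so of the three groups on this nitrogen only 1-isopropylpyrrolidin-3-yl gives a lower number than hydrogen. Nothing measured here accounts for the loss with methyl.

Open, on these data alone, is whether a longer chain such as ethyl fares like methyl. Also open, as far as these compounds go, is whether a simple amine on an ethyl chain would regain the lower number of compound 1.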